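The compounds below may be only part of what the source reports. "The series", "measured", "known", "first", "only" and "open" are said of these compounds alone.

Measured compounds:
- Compound 1, `COC(=O)C(C)n1n[n+]([O-])c2cc(C)c(C)cc21`. In a functional assay on KB cells (Homo sapiens) for inhibition, read by colorimetric assay, with a stated time of 72 h (a lower number here means that less compound is needed, a higher number that more compound is needed for the effect), compound 1 gives > 100 ug/mL, which is a limit of the assay and not a number.
- Compound 2, `Cc1cc2c(cc1C)[n+]([O-])nn2C`. In this assay compound 2 gives > 100 ug/mL, again a limit of the assay.
- Compound 3, `COC(=O)C(C)n1nc2c(n1)C(=O)C(C)=C(C)C2=O`. In this assay compound 3 gives 3.5 ug/mL.

Compound 1 and compound 2 share one core; compound 3 carries another core, and the difference between the two cores is not broken down here. Compound 1 and compound 2 both sit at the limit of > 100 ug/mL in this assay, at which 2 of the 3 values shown sit. The change from compound 1 to compound 2 is methyl in place of 1-(methoxycarbonyl)ethyl on an aromatic nitrogen, and the step that the two limits leave unreadable from compound 1 to compound 2 gives no readable size.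

Compound 4, `CC1=C(C)C(=O)c2nn(C)nc2C1=O`, is not yet measured. It arises from compound 3 by methyl in place of 1-(methoxycarbonyl)ethyl on an aromatic nitrogen. This is the same kind of change as that from compound 1 to compound 2, not the same change: in compound 1 the place is next to the ring nitrogen, two ring bonds from the ring nitrogen and two ring bonds from the ring atom that bears a group of 1 heavy atom, whereas in compound 3 it lies between two ring nitrogen atoms, two ring bonds from two ring atoms that each bear a fused ring.

Going by the values given here, the only earlier instance of the change leaves its size unreadable, so the expectation for compound 4 rests on compound 3 alone. Compound 4 is expected to stay near compound 3, with the estimated step of a 1.4-fold higher number from compound 3 to compound 4 (0.15 log units; within the scatter). In this assay compound 4 is estimated at 5 ug/mL, expected between 1.5 ug/mL and 20 ug/mL.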

Compound 4, concentration for half-maximal effect: 3 ug/mL
Compound 4: the middle estimate sits 1.7-fold (0.22 log units) above what was measured; the range from low to high includes it.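

In this assay, methyl in place of 1-(methoxycarbonyl)ethyl on the core of compound 3 gives a 1.2-fold lower number from compound 3 to compound 4 (0.07 log units; within the scatter), so on this core the exchange leaves the read-out within the scatter and the larger group is not required for a measurable value. The same kind of change on the core of compound 1 cannot be read, as compound 1 and compound 2 each stand at a limit of the assay and not at a number: the limit of > 100 ug/mL in this assay, at which 2 of the 4 values shown sit. This leaves one readable instance of the change, which shows its size on the core of compound 3 only and does not show whether that size carries over to or from the core of compound 1, where the place on the ring also differs.

The compounds shown leave open what a longer chain such as propyl, an amine, or a carboxylic acid in place of the methoxycarbonyl part would do on that aromatic nitrogen of the core of compound 3. They also leave open how far the ring methyl groups of that core matter, since both compounds measured on it carry them unchanged.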